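Replacing pyrrolidin-1-yl with 1H-imidazol-1-yl in compound 2

The source may hold more compounds than are shown below. What is called first, only, known or untested is meant among the compounds shown, and "the series" means these compounds.

In a functional assay on the whole organism for antagonist activity, with Mus musculus as the target (a higher number here means that more compound is needed for the effect, a lower number that less compound is needed), compound 1 (`CN1CCN(CC#CCn2ccnc2)C1=O`) returns > 100 mg/kg as its result, and that value is a limit, not a number. Going by the values given here, compound 2 (`CC(C#CCN1CCCC1)N1CCN(C)C1=O`) gives 4.5 mg/kg in this assay and so supplies the only actual number so far.

Compound 3 (`CC(C#CCn1ccnc1)N1CCN(C)C1=O`) is reached from compound 2 by a single exchange. The change 1H-imidazol-1-yl in place of pyrrolidin-1-yl on a saturated chain carbon bound to a triple-bonded carbon puts 1H-imidazol-1-yl in place of pyrrolidin-1-yl on a saturated chain carbon bound to a triple-bonded carbon. Among the compounds with values here, no measured step between compounds differing in one place is available to size this exchange.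

Compound 1 also carries 1H-imidazol-1-yl, and its result stands at the limit of > 100 mg/kg in this assay, at which 1 of the 2 values shown sits, and so points to a large rise in the dose needed for compound 3. The expected size is well beyond the scatter, with an estimated 16-fold higher number from compound 2 to compound 3 (1.19 log units; beyond the scatter) in this assay. For compound 3 the estimate is 70 mg/kg in this assay, with an expected range of 20 mg/kg to 250 mg/kg and a real chance that only a limit is reported.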

Compound 3, dose for half-maximal effect: 21 mg/kg
Beside the measured number, compound 3's estimate is 3.3-fold (0.52 log units) above it, and the stated range covers the measured number.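

In this assay, the exchange of pyrrolidin-1-yl for 1H-imidazol-1-yl on a saturated chain carbon bound to a triple-bonded carbon now has a measured size: a 4.7-fold higher number from compound 2 to compound 3 (0.67 log units; beyond the scatter). The exchange raises the dose needed, yet compound 3 still gives a real number rather than a limit. With 1H-imidazol-1-yl held fixed, methyl in place of hydrogen on a saturated chain carbon bound to an amide-type nitrogen in a ring and a triple-bonded carbon also counts, and this step can be read only as a minimum size, as compound 1 stands at a limit: an at least 4.7-fold lower number from compound 1 to compound 3 (0.67 log units; beyond the scatter), with the limit in the series as follows: the limit of > 100 mg/kg in this assay, at which 1 of the 3 values shown sits.

Still open, as far as these compounds go, is the size of the methyl step with pyrrolidin-1-yl in place, and whether it matches the step seen with 1H-imidazol-1-yl. Also open, from the compounds shown here alone, is where a piperidin-1-yl group or an open-chain dimethylamino group would fall relative to compound 2, and what an ethyl group would do in place of that methyl.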